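The compounds below may be only part of what the source reports. "The series", "measured", "known", "first", "only" and "open" are said of these compounds alone.

Measured compounds:
Compound 1, `O=C(COc1ccc2cc(/C=C3/SC(=O)NC3=O)ccc2c1)Nc1ccc(Br)cc1F`, gives 1900 nM.
Compound 2, `O=C(COc1ccc2cc(/C=C3/SC(=O)NC3=O)ccc2c1)Nc1cccc(F)n1`, gives 840 nM.

Both numbers come from an assay on isolated protein for inhibition of histone deacetylase 4 (Homo sapiens), with a stated time of 1 h; on this read-out higher numbers stand for weaker inhibition and lower numbers for stronger inhibition. Compound 2 stands at the lowest number of the two; its nearest neighbour is compound 1, and the gap between them is a 2.3-fold lower number from compound 1 to compound 2 (0.35 log units; beyond the scatter), a modest but real difference. Compound 3, `Cc1cc(Br)ccc1NC(=O)COc1ccc2cc(/C=C3/SC(=O)NC3=O)ccc2c1`, has not yet been measured in this assay. It differs from compound 2 by 4-bromo-2-methylphenyl in place of 6-fluoropyridin-2-yl on an amide-type nitrogen. Going by the values given here, only one measured step bears on this change, namely a 2.3-fold lower number from compound 1 to compound 2 (0.35 log units; beyond the scatter), in which 6-fluoropyridin-2-yl took the place of a bromine-bearing phenyl on the same amide-type nitrogen. Compound 3 brings back a bromine-bearing phenyl group, closer in kind to the group of compound 1 than to that of compound 2, so the expected direction is back toward the higher number of compound 1, a modest rise rather than a further fall. The account therefore expects compound 3 to give about 1700 nM in this assay, with a likely range from 700 nM to 4000 nM. That estimate corresponds to an expected step of a 2.0-fold higher number from compound 2 to compound 3 (0.31 log units; beyond the scatter).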

Compound 3, half-maximal inhibitory concentration: 550 nM
Compound 3: middle estimate off by 3.1-fold (0.49 log units), on the high side; measured number below the stated range.
By their numbers in this assay, from the lowest: compounds 3 and 2 (each within the scatter of the next); then compound 1.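

In this assay, 4-bromo-2-methylphenyl in place of 6-fluoropyridin-2-yl on the amide-type nitrogen gives a 1.5-fold lower number from compound 2 to compound 3 (0.18 log units; within the scatter), so a ring of carbon only, with no hydrogen-bond acceptor in this group, serves as well here as the fluorinated pyridine group did. The bromine-bearing phenyl groups also turn out not to behave alike: methyl in place of fluoro on an aromatic carbon gives a 3.5-fold lower number from compound 1 to compound 3 (0.54 log units; beyond the scatter), a change in a single small substituent that is enough to separate compound 3 from compound 1 while the bromine stays. The higher number of compound 1 therefore cannot be read as a mark of bromine-bearing phenyl groups in general, and nothing available here accounts for either step.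

From the compounds shown here alone, it remains open whether a chlorine, a methoxy group or an ethyl group in the place of that methyl would match or pass compound 3, and whether the methyl would give a similar step with the bromine gone. It is equally open how an amine or a carboxylic acid on this ring would fare, since the groups shown at this position carry only halogens and methyl.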